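The source may report more compounds than this note shows. Statements on the series, on what has been measured and on what is new or still open speak of the compounds shown alone.

Of the compounds shown here, three from this series have been tested in a functional assay on CCRF-CEM cells (Homo sapiens) for antiproliferative activity, read by MTT assay, with a stated time of 72 h; on this read-out lower numbers stand for stronger inhibition and higher numbers for weaker inhibition. Compound 1 `COc1ccc([C@@H]2CC(=O)c3c(OC)cc(OC)c(CC=C(C)C)c3O2)cc1` gives 5 ug/mL in this assay. Compound 2 `CCCCCOc1ccc([C@@H]2CC(=O)c3c(OC)cc(OCCCCC)c(CC=C(C)C)c3O2)cc1` gives 4.3 ug/mL, the lowest of the three numbers, although its distance from compound 1 lies within the usual scatter, so the two cannot be ranked. Compound 3 `CC(=O)Oc1ccc(C2CC(=O)c3c(O)cc(OC(C)=O)c(CC=C(C)C)c3O2)cc1` gives 37 ug/mL, a gap beyond the scatter from compound 2.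

The next compound, compound 4 `CCCCCOc1cc(OC)c2c(c1CC=C(C)C)O[C@H](c1ccc(O)cc1)CC2=O`, is not yet measured. It differs from compound 2 in one place: hydrogen in place of pentyl on an oxygen on an aromatic ring. Hydrogen in place of pentyl on an oxygen on an aromatic ring turns the pentyloxy group into a hydroxy group, while the rest of the shared core is unchanged.

Within the data shown here, no step between measured compounds that differ in a single place is available, so there is no direct precedent for this exchange. The step from compound 2 to compound 4 in this assay is expected to be small, a 1.4-fold higher number from compound 2 to compound 4 (0.14 log units; within the scatter), with at most a slight move toward a higher number. Compound 4 is therefore estimated at 6 ug/mL, in a range from 2.5 ug/mL to 15 ug/mL.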

Compound 4, concentration for 50% inhibition: 5.4 ug/mL
Compound 4: middle estimate off by 1.1-fold (0.05 log units), on the high side, within the range that was stated.
By their numbers in this assay, from the lowest: compounds 2, 1 and 4 (each within the scatter of the next); then compound 3.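

In this assay the exchange of pentyl for hydrogen on this oxygen, which turns the 4-(pentyloxy)phenyl group into a 4-hydroxyphenyl group, gives a step that cannot be told apart from the scatter (a 1.3-fold higher number from compound 2 to compound 4 (0.10 log units; within the scatter)). Among these compounds, this is the first comparison in which only one place differs, and it shows that, in this cell test, this oxygen can carry either the pentyl chain or a hydrogen with no readable difference in the number. No measurement is at hand that would explain why the two compounds read alike.

Whether the same holds for the pentyloxy group that compound 4 keeps remains open, since no single-place exchange at that group is shown. Also open, going by these compounds, is how a longer chain such as decyl, or a chain ending in an amine or a carboxylic acid, would read on the oxygen studied here.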